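Methyl for tert-butoxy on a carbonyl carbon

This account rests on a few compounds, and the source may have more. Where it says the series, first, only, none or still open, it means among the compounds named here.

compound 1 `COc1ccc(-c2c(C)nc3c(N4CC[C@@H](NS(C)(=O)=O)C4)cc(C)nn23)cc1OC` gives > 95%
compound 2 `COc1ccc(-c2c(C)nc3c(N4CC[C@@H](OC(C)=O)C4)cc(C)nn23)cc1OC` gives > 95%
compound 3 `COc1ccc(-c2c(C)nc3c(N4CCN(C(=O)OC(C)(C)C)CC4)cc(C)nn23)cc1OC` gives > 95%

All three readings come from an ADME assay on microsomes from liver (Homo sapiens) for metabolic stability, read by LC-MS, with NADPH named in the record, with a stated time of 60 min, tested at 1 uM, in the absence of a further agent (a higher number here means that more of the compound is left, a lower number that less of the compound is left), and each is a limit of the assay, not a number. Compound 3 stands at > 95% as such a limit. The whole set shows the limit of > 95% in this assay, at which 3 of the 3 values shown sit, and so offers no ranking among its members.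

The change from compound 3 to compound 4 `COc1ccc(-c2c(C)nc3c(N4CCN(C(C)=O)CC4)cc(C)nn23)cc1OC` is methyl in place of tert-butoxy on a carbonyl carbon (methyl in place of tert-butoxy on a carbonyl carbon, or tert-butoxycarbonyl to acetyl). Within the data shown here, the only measured step is a step that the two limits leave unreadable from compound 1 to compound 2 and it concerns acetoxy in place of methanesulfonamido on a saturated ring carbon. That is a different change, and it has no size to carry over.

Resting on compound 3 at > 95% as a limit, no step beyond the usual scatter is expected, and no direction can be foretold. In this assay the estimated step is a number no higher from compound 3 to compound 4 (the limit leaves the size open) and it is expected to stay within that scatter. For compound 4 the expected value is 95% with an estimated range from 83% to 100% for its reading.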

Compound 4, percent of the compound remaining: > 95%
Compound 4 was reported as a limit; the forecaster's own chance of this, stated with the estimate: 55%; the middle value sits exactly at the limit.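

In this assay compound 4 gives > 95% as a limit of the assay, not a number. Among these compounds, no step from compound 1, compound 2 or compound 3 to compound 4 can be read, because all four values sit at one limit: the limit of > 95% in this assay, at which 4 of the 4 values shown sit. The compounds shown leave open whether tert-butoxycarbonyl to acetyl, or any other change among them, alters the percent of compound remaining.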